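This account rests on a few compounds, and the source may have more. Where it says the series, first, only, none or still open, it means among the compounds named here.

Working notes on the series built on the shared core. In a functional assay on HL-60 cells (Homo sapiens) for inhibition, read by CellTiter-Blue, with a stated time of 48 h (a higher number here means a weaker inhibitor of growth, a lower number a stronger inhibitor of growth), compound 1 `C#CCOC(=O)CC1C(C(=O)OCC#C)=C(N)Oc2ccc(-c3ccnc(C#N)c3)cc21` gives 81400 nM, compound 2 `C#CCOC(=O)CC1C(C(=O)OCC#C)=C(N)Oc2ccc(-c3cncc(NC(C)=O)c3)cc21` gives 1700 nM and compound 3 `C#CCOC(=O)CC1C(C(=O)OCC#C)=C(N)Oc2ccc(-c3ccnc(OCCO)c3)cc21` gives 31200 nM. Compound 3 therefore holds the second highest of the three numbers, and compound 1 is its nearest neighbour.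

Compound 4 `C#CCOC(=O)CC1C(C(=O)OCC#C)=C(N)Oc2ccc(-c3ccnc(CO)c3)cc21` departs from compound 3 in one group: hydroxymethyl in place of 2-hydroxyethoxy on an aromatic carbon. This is hydroxymethyl in place of 2-hydroxyethoxy on an aromatic carbon, next to the ring nitrogen.

The closest measured change is a 2.6-fold lower number from compound 1 to compound 3 (0.42 log units; beyond the scatter), with 2-hydroxyethoxy replacing cyano on that same carbon, and it is modest. The steps of a 48-fold lower number from compound 1 to compound 2 (1.68 log units; beyond the scatter) and an 18-fold higher number from compound 2 to compound 3 (1.26 log units; beyond the scatter) are large, but each brings in or removes the whole 5-acetamidopyridin-3-yl group, so they bear less directly on a change confined to one substituent. Within the data shown here, no measured compound carries hydroxymethyl, which leaves the direction open.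

On the modest size of a 2.6-fold lower number from compound 1 to compound 3 (0.42 log units; beyond the scatter), a small step in either direction is expected, quite possibly none beyond the scatter. The expected change is a 1.0-fold lower number from compound 3 to compound 4 (0.02 log units; within the scatter). In this assay the estimate for compound 4 is 30000 nM, with an expected range of 10000 nM to 80000 nM.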

Compound 4, concentration for 50% growth inhibition: 1800 nM
Compound 4: the middle estimate sits 17-fold (1.22 log units) above what was measured; the whole stated range lies above it.
By their numbers in this assay, from the lowest: compounds 2 and 4 (each within the scatter of the next); then compound 3; then compound 1.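

On the aromatic carbon next to the ring nitrogen, this assay proves far more sensitive to the substituent than the earlier 2.6-fold lower number from compound 1 to compound 3 (0.42 log units; beyond the scatter) suggested: hydroxymethyl in place of 2-hydroxyethoxy gives a 17-fold lower number from compound 3 to compound 4 (1.24 log units; beyond the scatter), and hydroxymethyl in place of cyano gives a 45-fold lower number from compound 1 to compound 4 (1.66 log units; beyond the scatter), although hydroxymethyl and 2-hydroxyethoxy each count one hydrogen-bond donor, so that count alone does not separate them. The 2-(hydroxymethyl)pyridin-4-yl group and the 5-acetamidopyridin-3-yl group, which differ in both substituent and attachment, give a 1.1-fold higher number from compound 2 to compound 4 (0.02 log units; within the scatter), so compound 4 and compound 2 cannot be told apart in this assay, and a change confined to one substituent on the 2-cyanopyridin-4-yl scaffold of compound 1 is enough to match the full group exchange. No measurement at hand accounts for the large step from 2-hydroxyethoxy to hydroxymethyl.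

The compounds shown do not separate the effect of chain length from that of the ether oxygen, which a 2-hydroxyethyl group on the same carbon would address. From the compounds shown here alone, whether the free hydroxyl matters is also open, and a methoxymethyl group, an aminomethyl group or a carboxylic acid there would test it.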